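The source may hold more compounds than are shown below. What is called first, only, known or untested is meant among the compounds shown, and "the series" means these compounds.

Measured in an ADME assay on Left cardiac atrium (Cavia porcellus); on this read-out lower numbers stand for an effect already at smaller amounts and higher numbers for an effect only at larger amounts of compound:

Compound 1 `CCOC(=O)C1=C(C)NC(C)=C(C(=O)OCC)C1c1c(-c2ccc(F)cc2)nc2sccn12` gives 64 nM.
Compound 2 `CCOC(=O)C1=C(C)NC(C)=C(C(=O)OCC)C1c1c(-c2ccc(F)cc2)nc2sc(Cl)cn12` gives 49 nM.
Compound 3 `CCOC(=O)C1=C(C)NC(C)=C(C(=O)OCC)C1c1c(-c2cc(F)c(F)cc2F)nc2sccn12` gives 160 nM.

Compound 2 has the smallest of the three numbers, but a 1.3-fold lower number from compound 1 to compound 2 (0.12 log units; within the scatter), so compounds 1 and 2 cannot be told apart; only compound 3 sits clearly higher. Compound 4 `CCOC(=O)C1=C(C)NC(C)=C(C(=O)OCC)C1c1c(-c2ccc(Cl)cc2)nc2sc(Cl)cn12` differs from compound 2 by chloro in place of fluoro on an aromatic carbon. Among the measured compounds shown here, no measured pair shows exactly this swap. Two steps come close. The step of a 1.3-fold lower number from compound 1 to compound 2 (0.12 log units; within the scatter) also adds a chloro, though on the other ring system, and changed little. The step of a 2.5-fold higher number from compound 1 to compound 3 (0.40 log units; beyond the scatter) alters the fluorinated phenyl ring and shifted the number moderately upward, which shows that this ring is not indifferent to change. Taken together, a small move in this assay is expected, most likely toward a somewhat higher number, but one that may well stay within the scatter. Compound 4 is therefore estimated at 65 nM, with a range from 25 nM to 170 nM. This estimate corresponds to an expected step of a 1.3-fold higher number from compound 2 to compound 4 (0.12 log units; within the scatter).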

Compound 4, half-maximal effective concentration: 3500 nM
For compound 4 the middle estimate is 54-fold (1.73 log units) below the measured one; measured number above the stated range.
By their numbers in this assay, from the lowest: compounds 2 and 1 (each within the scatter of the next); then compound 3; then compound 4.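

Among the compounds shown here, the 4-fluorophenyl group proves far less forgiving than the earlier compounds suggested: in this assay, changing it to 4-chlorophenyl gives a 71-fold higher number from compound 2 to compound 4 (1.85 log units; beyond the scatter) even though only fluoro gives way to chloro, with no change in rings, hydrogen-bond donors, hydrogen-bond acceptors or net charge. This step is much larger than a 2.5-fold higher number from compound 1 to compound 3 (0.40 log units; beyond the scatter) on replacing 4-fluorophenyl with 2,4,5-trifluorophenyl, and it contrasts with a 1.3-fold lower number from compound 1 to compound 2 (0.12 log units; within the scatter) on adding a chloro elsewhere on the core, so in these compounds the effect of a chloro depends strongly on where it sits. No available measurement explains why this single exchange matters so much.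

Going by these compounds, the 4-chlorophenyl group appears here only together with the second chloro of compound 2, so it remains open whether the same jump would occur on the core of compound 1. Also open, on these data alone, is how a methyl group, a methoxy group or an amine would read on this carbon, and therefore whether fluoro is especially favourable there or chloro is especially poor.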